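Trifluoromethyl on the phenyl ring of the hydroxylated core

This account rests on a few compounds, and the source may have more. Where it says the series, first, only, none or still open, it means among the compounds named here.

Compound 3 `CC1=C(/C=C/C(=O)/C=C/c2ccccc2)C(C)(C)CCC1O` sits second highest of the three numbers at hand: in a functional assay on CWR22R cells (Homo sapiens) for cytotoxicity, read by MTT assay, with a stated time of 72 h (a lower number here means a stronger inhibitor, a higher number a weaker inhibitor), compound 3 gives 8000 nM. Compound 1 `CC1=CCCC(C)(C)C1/C=C/C(=O)/C=C/c1ccccc1C(F)(F)F` gives 18400 nM, and compound 2 `CC1=CCCC(C)(C)C1/C=C/C(=O)/C=C/c1ccc(C(F)(F)F)cc1` gives 3300 nM; both carry a trifluoromethyl, and their values differ in this assay. Compound 4 `CC1=C(/C=C/C(=O)/C=C/c2ccccc2C(F)(F)F)C(C)(C)CCC1O` is compound 3 with trifluoromethyl in place of hydrogen on an aromatic carbon. Going by the values given here, no matched pair isolates this change on the hydroxylated core. Given that compound 1, with the same substituent placement, gives 18400 nM, a modest step towards a higher number is expected, a 1.5-fold higher number from compound 3 to compound 4 (0.18 log units; within the scatter), though a result within the scatter would not surprise. Compound 4 is estimated at 12000 nM, with a range from 5000 nM to 30000 nM.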

Compound 4, half-maximal inhibitory concentration: 2300 nM
Beside the measured number, compound 4's estimate is 5.2-fold (0.72 log units) above it; the whole stated range lies above it.
By their numbers in this assay, from the lowest: compounds 4 and 2 (each within the scatter of the next); then compound 3; then compound 1.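

In this assay, trifluoromethyl in place of hydrogen on an aromatic carbon, ortho to a large group, gives a 3.5-fold lower number from compound 3 to compound 4 (0.54 log units; beyond the scatter) on the shared core. Going by these compounds alone, this is the first comparison that isolates a single change, and at this position the group goes with a stronger inhibitor rather than a weaker one. Nothing measured here explains the step.

Open, as far as these compounds go, is whether chlorine or a methoxy group at the same position would give a similar step. Also open, from the compounds shown here alone, is whether trifluoromethyl gives this step on any other core.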